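Swapping a Nitrile for Fluorines on a Shared Core

This account rests on a few compounds, and the source may have more. Where it says the series, first, only, none or still open, it means among the compounds named here.

Compound 1 `N#Cc1ccc(-c2csc(N/N=C\c3cccc4ccccc34)n2)cc1` has been tested in an in vitro assay on BTI-TN-5B1-4 cells for inhibition of Amine oxidase [flavin-containing] A (Homo sapiens), read by Amplex Red, with a stated time of 15 min, tested at 100 uM (on this read-out lower numbers stand for less inhibition and higher numbers for more inhibition at the one concentration tested (going by the name of the read-out)), where compound 1 gives 40%. Compound 2 `C/C(=N/Nc1nc(-c2ccc(F)cc2F)cs1)c1cccnc1` gives 40% in this assay, so compound 1 stands level with compound 2 within the usual scatter. Compound 3 `Fc1ccc(-c2csc(N/N=C\c3cccc4ccccc34)n2)c(F)c1` has not yet been measured. It differs from compound 1 in one place: 2,4-difluorophenyl in place of 4-cyanophenyl on an aromatic carbon. Compound 2 already carries the entering group on the shared core and gives 40%, a value no different from compound 1. On that showing the step is expected to be no change at the digits printed from compound 1 to compound 3 (within the scatter), none beyond the scatter. Compound 3 is therefore expected to give 40%, within 22% to 58%.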

Compound 3, a percentage reported as inhibition, at one concentration (the size of the read-out at that concentration, not a potency): 40%
The estimate for compound 3 equals the measured number at the digits printed; measured number inside the range.
By their numbers in this assay, from the lowest: compounds 1, 2 and 3 (each within the scatter of the next).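

Putting 2,4-difluorophenyl in place of 4-cyanophenyl, on the aromatic carbon next to the ring nitrogen, gives no change at the digits printed from compound 1 to compound 3 (within the scatter) in this assay, a direct comparison on one core that compound 2, which differs from compound 1 in more than one place, could not give. At this position, then, the nitrile-bearing ring and the difluorinated ring read alike at the one concentration tested. Nothing available here bears on why this is so. On these data alone, whether an amine, a carboxylic acid or an unsubstituted phenyl at this carbon would read the same remains open.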